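Crotonamide Quinazolines: Swapping the Basic Amine

The source may hold more compounds than are shown below. What is called first, only, known or untested is meant among the compounds shown, and "the series" means these compounds.

Measured compounds:
Compound 1 `C/C=C/C(=O)Nc1cc2c(N3CCCc4ccccc43)ncnc2cc1OC` gives 7520 nM in a functional assay on PC-3 cells (Homo sapiens) for antiproliferative activity, read by MTT assay, with a stated time of 72 h; a lower number here means a stronger inhibitor, a higher number a weaker inhibitor.
Compound 2 `COc1cc2ncnc(N3CCCc4ccccc43)c2cc1NC(=O)/C=C/C(C)C` gives 8430 nM in this assay.
Compound 3 `COc1cc2ncnc(N3CCCc4ccccc43)c2cc1NC(=O)/C=C/CN(C)C` gives 1750 nM in this assay.

Compound 3 holds the lowest number of the three, separated from compound 1 and compound 2 by steps beyond the scatter. Compound 4 `COc1cc2ncnc(N3CCCc4ccccc43)c2cc1NC(=O)/C=C/CN1CCN(C)CC1` differs from it by 4-methylpiperazin-1-yl in place of dimethylamino on a saturated chain carbon bound to a double-bonded chain carbon. Going by the values given here, the steps that bear on this are a 4.3-fold lower number from compound 1 to compound 3 (0.63 log units; beyond the scatter) and a 4.8-fold lower number from compound 2 to compound 3 (0.68 log units; beyond the scatter), both showing that adding the dimethylamino group lowers the number modestly. Among the compounds with values here, no measured step compares one amine with another, so the size of this change is uncertain; the expectation is a step of a 1.3-fold higher number from compound 3 to compound 4 (0.10 log units; within the scatter), within the scatter. Compound 4 is therefore expected to give 2200 nM, with a range from 900 nM to 5500 nM.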

Compound 4, half-maximal inhibitory concentration: 6260 nM
Estimate against measurement, compound 4: 2.8-fold (0.45 log units) below; measured number above the stated range.
By their numbers in this assay, from the lowest: compound 3; then compounds 4, 1 and 2 (each within the scatter of the next).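

In this assay, the lower number seen with dimethylamino on this saturated chain carbon does not carry over to 4-methylpiperazin-1-yl, which gives a 3.6-fold higher number from compound 3 to compound 4 (0.55 log units; beyond the scatter) in this comparison. The choice of amine therefore matters at this position, since compound 4 stands level with the compounds lacking an amine on this chain (a 1.2-fold lower number from compound 1 to compound 4 (0.08 log units; within the scatter) and a 1.3-fold lower number from compound 2 to compound 4 (0.13 log units; within the scatter)). No measurement available here accounts for the difference between the two amines. Still open, as far as these compounds go, is whether piperidine, morpholine or diethylamino at this carbon would behave like dimethylamino or like 4-methylpiperazin-1-yl.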